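The compounds below may be only part of what the source reports. "The series", "measured", "known", "first", "only" and "open" are said of these compounds alone.

Values in a functional assay on brain (Rattus norvegicus, strain Wistar) for inhibition; a higher number here means a weaker inhibitor, a lower number a stronger inhibitor:
compound 1 `CCCc1ccc(-c2c(C)[nH]c(=O)n2C)cc1`: 21500 nM
compound 2 `Cc1[nH]c(=O)n(C)c1-c1ccc(CC(C)C)cc1`: 7800 nM
compound 3 `CCCCCCc1ccc(-c2c(C)[nH]c(=O)n2C)cc1`: 9000 nM

Compound 3 sits at the lower end of this small set. The data show a 2.4-fold lower number from compound 1 to compound 3 (0.38 log units; beyond the scatter), a modest change beyond the scatter, which came with propyl in place of hydrogen on the chain. They also show a 1.2-fold higher number from compound 2 to compound 3 (0.06 log units; within the scatter), which lies within the scatter, so compound 2 and compound 3 cannot be told apart.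

The next compound, compound 4 `CCCCCCCCc1ccc(-c2c(C)[nH]c(=O)n2C)cc1`, lengthens the chain of compound 3: ethyl in place of hydrogen on a saturated chain carbon, six bonds along the chain from an aromatic carbon. This is ethyl in place of hydrogen on a saturated chain carbon, six bonds along the chain from an aromatic carbon.

Within the data shown here, two measured steps bear on this change. The first is the chain extension already described. The second, a 2.8-fold lower number from compound 1 to compound 2 (0.44 log units; beyond the scatter), is also modest and came with a single added methyl. Against any steady gain from added chain carbons stands compound 3, which shows no separation from compound 2. With so few compounds, only a small move towards a lower number in this assay is expected, probably no larger than the scatter. The expected step is a 1.4-fold lower number from compound 3 to compound 4 (0.14 log units; within the scatter). Compound 4 is estimated at 6500 nM, with an expected range from 2800 nM to 15000 nM.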

Compound 4, half-maximal inhibitory concentration: 19400 nM
Compound 4: middle estimate off by 3.0-fold (0.47 log units), on the low side; measured number outside the range, above it.
By their numbers in this assay, from the lowest: compounds 2 and 3 (each within the scatter of the next); then compounds 4 and 1 (each within the scatter of the next).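

In this assay, the ethyl added on the saturated chain carbon, six bonds along the chain from an aromatic carbon, gave a 2.2-fold higher number from compound 3 to compound 4 (0.33 log units; beyond the scatter) and so turned back the earlier fall in the number that came with propyl on the chain of compound 1. Lengthening the straight chain therefore gives no steady gain across compound 1, compound 3 and compound 4: the full extension amounts to a 1.1-fold lower number from compound 1 to compound 4 (0.04 log units; within the scatter) and so leaves no separation, while the comparison with the branched chain gives a 2.5-fold higher number from compound 2 to compound 4 (0.40 log units; beyond the scatter) and shows the longest chain on the weaker side. Nothing available here accounts for this reversal.

The compounds shown leave open whether a longer chain would raise the number further or level off, and whether the reversal holds for branched chains of similar length. They also leave open how a chain ending in an amine or a carboxylic acid would behave at this position.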